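The source may hold more compounds than are shown below. What is called first, only, known or untested is meant among the compounds shown, and "the series" means these compounds.

In a functional assay on MGC-803 cells (Homo sapiens) for inhibition, read by sulforhodamine B assay (on this read-out higher numbers stand for weaker inhibition and lower numbers for stronger inhibition), the compounds share one core and differ in the group on a double-bonded ring carbon. Compound 1 `O=C1C(N2CCCCC2)=CC(=O)c2c1nc1n2[C@H]2OC[C@@H](O)[C@H]2OC1` carries piperidin-1-yl there. In this assay compound 1 gives only a limit of the assay, > 4000 nM, which is the limit of > 4000 nM in this assay, at which 1 of the 3 values shown sits. Compound 3 `O=C1C(Nc2ccccc2F)=CC(=O)c2c1nc1n2[C@H]2OC[C@@H](O)[C@H]2OC1` carries (2-fluorophenyl)amino in place of piperidin-1-yl, and in this assay compound 3 gives 2000 nM. For the measured compounds named here, the only measured step, an at least 2.0-fold lower number from compound 1 to compound 3 (0.30 log units; that floor lies within the scatter), starts from the bound given for compound 1, and its true size is therefore unknown. Compound 2 `O=C1C=C(Nc2cccc(Cl)c2)C(=O)c2c1nc1n2[C@H]2OC[C@@H](O)[C@H]2OC1` carries (3-chlorophenyl)amino, and in this assay compound 2 gives 1770 nM. That is the lowest of the two numbers reported, but the value of compound 3 lies within the scatter of it, so no order between the two can be claimed.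

Compound 4 `O=C1C=C(Nc2ccc(Br)cc2)C(=O)c2c1nc1n2[C@H]2OC[C@@H](O)[C@H]2OC1` differs from compound 2 by 4-bromophenyl in place of 3-chlorophenyl on an amine nitrogen. Going by the values given here, no measured step changes the halogen or its position on the aryl ring; the step from piperidin-1-yl to (2-fluorophenyl)amino replaces the whole group and does not bear on this exchange. With nothing to point either way, compound 4 is expected to stay within the scatter of compound 2, a step of a 1.0-fold higher number from compound 2 to compound 4 (0.01 log units; within the scatter). The estimate for compound 4 in this assay is 1800 nM, between 800 nM and 4000 nM.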

Compound 4, half-maximal inhibitory concentration: 1010 nM
The estimate for compound 4 lay 1.8-fold (0.25 log units) above the measured number, within the range that was stated.
By their numbers in this assay, from the lowest: compounds 4, 2 and 3 (each within the scatter of the next). At a limit, above all of these: compound 1.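

In this assay, for the compounds shown here, the new step is the first to keep the arylamino link and alter only the aryl group: a 1.8-fold lower number from compound 2 to compound 4 (0.24 log units; within the scatter). So at this amine nitrogen, 4-bromophenyl and 3-chlorophenyl cannot be told apart, even though the halogen and its printed ring position both change in this one exchange, and the two aryl groups have the same count of heavy atoms. The step therefore gives no sign that either the halogen or its position matters here, although two changes made together could also offset each other, and no measured value explains the size of the step.

What the compounds leave open is how each change acts alone, which 4-chlorophenyl or 3-bromophenyl on the same amine nitrogen would separate, and whether a plain phenyl without any halogen would stay within the scatter of these values. They also leave open how far this tolerance extends beyond halogenated phenyl groups, for example to a methoxy group or a carboxylic acid on the aryl ring, or to a benzyl group on the nitrogen.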